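A few compounds are considered here, and "the series" means these few. Any claim that something is new, unique, unknown or untested is made for them only; others in the source may bear on it.

The measured compounds and their values:

Compound 1, `COc1ccc(-c2ccc(-c3ccc(-c4nc5ccccc5[nH]4)cc3)cc2)cc1`, gives 100000 nM in a functional assay on DWD cells (Homo sapiens) for inhibition, read by sulforhodamine B assay; a higher number here means a weaker inhibitor of growth, a lower number a stronger inhibitor of growth.
Compound 2, `COc1ccc(-c2ccc(-c3ccc(-c4nc5ccccc5[nH]4)cc3)cc2)cc1OC`, gives 42100 nM in this assay.
Compound 3, `COc1ccc(-c2ccc(-c3ccc(-c4nc5c(O)cccc5[nH]4)cc3)cc2)cc1OC`, gives 1400 nM in this assay.

Compound 2 differs from compound 1 by a single change, (methoxy in place of hydrogen on an aromatic carbon), and this change brought a 2.4-fold lower number from compound 1 to compound 2 (0.38 log units; beyond the scatter). Compound 3 then adds a hydroxy group on the shared core, and that change brought a 30-fold lower number from compound 2 to compound 3 (1.48 log units; beyond the scatter), leaving compound 3 with the lowest number of the three by a clear margin.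

Compound 4, `COc1cc(-c2ccc(-c3ccc(-c4nc5c(O)cccc5[nH]4)cc3)cc2)cc(OC)c1OC`, has not yet been measured. It differs from compound 3 by methoxy in place of hydrogen on an aromatic carbon. Within the data shown here, this is the same kind of change as the one from compound 1 to compound 2: in both a methoxy group enters on an aromatic carbon of a six-membered aromatic ring of carbon only, ortho to a methoxy group and meta to a large group. The surroundings are not identical, however: in compound 4 the new methoxy group is also meta to a methoxy group, which is not so in compound 2. The difference between the core of compound 1 and the core of compound 3 is not broken down here.

Because a 2.4-fold lower number from compound 1 to compound 2 (0.38 log units; beyond the scatter) was modest, the step from compound 3 to compound 4 is expected to be modest as well, estimated at a 1.4-fold lower number from compound 3 to compound 4 (0.15 log units; within the scatter). For compound 4 in this assay the expected value is 1000 nM, with a range from 300 nM to 3500 nM.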

Compound 4, concentration for 50% growth inhibition: 190 nM
Compound 4: middle estimate off by 5.3-fold (0.72 log units), on the high side; measured number outside the range, below it.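

The methoxy group entering on compound 3 gave a 7.4-fold lower number from compound 3 to compound 4 (0.87 log units; beyond the scatter) in this assay, so the number fell on this core as it did in the earlier step on the core of compound 1. The size of the step, however, did not carry over from one core to the other: the same change on two cores in this assay, a 2.4-fold lower number (0.38 log units; beyond the scatter) from compound 1 to compound 2 and a 7.4-fold lower number (0.87 log units; beyond the scatter) from compound 3 to compound 4, 3.1-fold (0.49 log units) apart, beyond the scatter of two such steps These two pairs do not show what sets the size, since the core differs between them and the new methoxy group in compound 4 is also meta to a methoxy group, which is not so in compound 2, and the data cannot separate these two differences.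

A compound with the core of compound 1 and the same three methoxy groups as compound 4 would help to separate them, by showing whether the larger step needs the hydroxy group on the shared core. On these data alone, it also remains open whether another group entering on the same aromatic carbon, such as an ethoxy group, an amine or a fluorine atom, would lower the number as methoxy does on these two cores.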